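Series notes: methyl on the amine of compound 2

The source may report more compounds than this note shows. Statements on the series, on what has been measured and on what is new or still open speak of the compounds shown alone.

Compound 2 `CCS(=O)(=O)Nc1cccc2c1CCCC2CN` carries aminomethyl on a saturated ring carbon of the shared core. In an assay on isolated protein for binding affinity to Alpha-1D adrenergic receptor (Rattus norvegicus), read by radioligand binding (a higher number here means a weaker inhibitor, a lower number a stronger inhibitor), compound 2 gives < 10000 nM, which is a limit of the assay rather than a number. Compound 1 `CCS(=O)(=O)Nc1cccc2c1CCCC2c1c[nH]c(C)n1` in this assay gives < 10000 nM, likewise a limit. The step that the two limits leave unreadable from compound 1 to compound 2 therefore stays unreadable, as the limit of < 10000 nM in this assay, at which 2 of the 2 values shown sit, shows. Compound 3 `CCS(=O)(=O)Nc1cccc2c1CCCC2CNC` differs from compound 2 by methyl in place of hydrogen on an amine nitrogen. Among the compounds with values here, no measured step bears on this change, and both known values are limits, so no direction can be read from them. The estimate for compound 3 is 3000 nM, with a range from 300 nM to 10000 nM. This corresponds to an expected step that the limit leaves unreadable from compound 2 to compound 3, not beyond the scatter.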

Compound 3, inhibition constant: < 10000 nM
Compound 3: only a limit was reported (the forecaster's own chance of this, stated with the estimate: 40%); the middle value lies beyond the limit too.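

No new step can be read between compound 3 and compound 2 or compound 1, because all the values are limits: the limit of < 10000 nM in this assay, at which 3 of the 3 values shown sit.

On these data alone, whether methyl in place of hydrogen on the amine nitrogen shifts the result in this assay stays open.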